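A few compounds are considered here, and "the series" means these few. Any claim that something is new, unique, unknown or untested is made for them only; others in the source may bear on it.

Measured compounds in a functional assay on ileum for inhibition of histamine H1 receptor (Cavia porcellus); on this read-out lower numbers stand for stronger inhibition and higher numbers for weaker inhibition:
compound 1 `CCCOCCn1c(N2CCCN(C)CC2)nc2ccccc21` — 16 nM
compound 2 `CCCCOCCn1c(N2CCN(C)CC2)nc2ccccc21` — 38 nM
compound 3 `CCCCOCCn1c(N2CCCN(C)CC2)nc2ccccc21` — 10 nM

Compound 2 stands highest of the three numbers in this assay; compound 1 lies nearest to it, and compound 3 furthest, both below it by more than the scatter. The unmeasured compound 4 `CCCC(C)Cn1c(N2CCN(C)CC2)nc2ccccc21` differs from compound 2 by 1-methylbutyl in place of butoxymethyl on a saturated chain carbon bound to an aromatic nitrogen.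

Two measured steps are available. The step of a 1.6-fold lower number from compound 1 to compound 3 (0.20 log units; within the scatter) concerns a change on the chain, lengthening it by one methyl, and it stays within the scatter. The step of a 3.8-fold lower number from compound 2 to compound 3 (0.58 log units; beyond the scatter) concerns the ring attached to the core, not the chain, and it is modest. Within the data shown here, neither step removes the ether oxygen from the chain, so no measured step speaks directly to the change from compound 2 to compound 4. Among the measured compounds shown here, since the only chain change seen, from compound 1 to compound 3, stayed within the scatter, the step of a 1.3-fold higher number from compound 2 to compound 4 (0.12 log units; within the scatter) is expected to stay within the scatter as well, with no clear direction. Compound 4 is therefore estimated at 50 nM, in a range from 20 nM to 130 nM.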

Compound 4, half-maximal inhibitory concentration: 500 nM
The estimate for compound 4 lay 10-fold (1.00 log units) below the measured number; the whole stated range lies below it.
By their numbers in this assay, from the lowest: compounds 3 and 1 (each within the scatter of the next); then compound 2; then compound 4.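

Exchanging 2-butoxyethyl for 2-methylpentyl in this assay gives a 13-fold higher number from compound 2 to compound 4 (1.12 log units; beyond the scatter), so this position is sensitive to the make-up of the chain, not only to its length. Among these compounds, the only earlier chain change, a 1.6-fold lower number from compound 1 to compound 3 (0.20 log units; within the scatter), kept the ether oxygen, whereas here the oxygen leaves, the group goes from one hydrogen-bond acceptor to none, and the carbon count of the group stays at five. Nothing available explains the size of this step.

From the compounds shown here alone, the oxygen is lost and the methyl branch is gained in the same step, so the share of each remains open; a straight hexyl chain or a 3-methoxypropyl chain would bear on this. Also open, going by these compounds, is whether 4-methyl-1,4-diazepan-1-yl on the core would give the same result alongside 2-methylpentyl.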